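Compound 3: a larger group on the shared core

This account rests on a few compounds, and the source may have more. Where it says the series, first, only, none or still open, it means among the compounds named here.

In a toxicity assay on MT4 cells (Homo sapiens) for cytotoxicity (a lower number here means that less compound is tolerated, a higher number that more compound is tolerated), compound 1 `Cc1cn([C@H]2C=C[C@@H](COP(=O)(OCCSC(=O)C(C)(C)C)OCCSC(=O)C(C)(C)C)O2)c(=O)[nH]c1=O` gives > 10000 nM, which is a limit and not a number. Compound 2 `Cc1cn([C@H]2CC[C@@H](COP(=O)(OCCSC(=O)C(C)(C)C)OCCSC(=O)C(C)(C)C)O2)c(=O)[nH]c1=O` gives > 10000 nM, which is also a limit. Among the measured compounds shown here, the series so far stands at the limit of > 10000 nM in this assay, at which 2 of the 2 values shown sit. Compound 3 `CC(C)(C)C(=O)SCCOP(=O)(OCCSC(=O)C(C)(C)C)OC[C@@H]1C=C[C@H](n2cnc3c(N)ncnc32)O1` carries the change (a group of 10 heavy atoms (5 carbon, 5 nitrogen; one five-membered aromatic ring with 2 hetero atoms, one six-membered aromatic ring with 2 hetero atoms) in place of a group of 9 heavy atoms (5 carbon, 2 nitrogen, 2 oxygen; one six-membered aromatic ring with 2 hetero atoms), on a saturated ring carbon). For the measured compounds named here, no measured step shows what this replacement does in this assay. Going by the values given here, the only anchor is compound 1 at > 10000 nM, a limit, so no step beyond the scatter is expected. The expected change is a step that the limit leaves unreadable from compound 1 to compound 3. For compound 3 the estimated value is 12000 nM, with an expected range from 3000 nM to 50000 nM.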

Compound 3, half-maximal cytotoxic concentration: 9000 nM
Compound 3: the middle estimate sits 1.3-fold (0.12 log units) above what was measured, within the range that was stated.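

In this assay, among the compounds shown here, compound 3 gives 9000 nM, the first value that is a number and not a limit. Placing the group with a five-membered and a six-membered aromatic ring on this saturated ring carbon, next to the ring oxygen, in place of the group with one six-membered aromatic ring gives an at least 1.1-fold lower number from compound 1 to compound 3 (0.04 log units; that floor lies within the scatter), so no real change in the tolerated concentration can be claimed for this replacement. The floor of the step is all that can be read, and the remaining values in the series stay limits: the limit of > 10000 nM in this assay, at which 2 of the 3 values shown sit.

As far as these compounds go, what a plain amine or a carboxylic acid at this place would give in this assay stays open. Also open, from the compounds shown here alone, is whether any group on this carbon can move the number beyond the scatter, since steps that start from a limit cannot be sized.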